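The source may report more compounds than this note shows. Statements on the series, on what has been measured and on what is new or still open speak of the compounds shown alone.

Of the compounds shown here, three sharing one core have been measured in a functional assay on K562 cells (Homo sapiens) for cytotoxicity, read by fluorescence, with a stated time of 72 h; a higher number here means a weaker inhibitor, a lower number a stronger inhibitor: compound 1 (`CC(C)c1n[nH]c2c(NCc3ccc(-c4ccccn4)cc3)nc(S(C)(=O)=O)nc12`) gives 640 nM, compound 2 (`CC(C)c1n[nH]c2c(NCc3ccc(-c4ccccn4)cc3)nc(NCC(C)(C)O)nc12`) gives 29 nM, and compound 3 (`CC(C)c1n[nH]c2c(NCc3ccc(-c4ccccn4)cc3)nc(N[C@@H]3CCCC[C@H]3N)nc12`) gives 175 nM. Compound 3 therefore holds the middle place among the three numbers. The next structure, compound 4 (`COc1ccc(CNc2nc(NCc3ccc(-c4ccccn4)cc3)c3[nH]nc(C(C)C)c3n2)cc1`), carries 4-methoxybenzyl in place of 2-aminocyclohexyl on a nitrogen on an aromatic ring. Going by the values given here, no measured step makes this exact exchange. The closest evidence is a 6.0-fold higher number from compound 2 to compound 3 (0.78 log units; beyond the scatter), a change at the same place that shows this substituent can move the number. Replacing methylsulfonyl gave a 22-fold lower number from compound 1 to compound 2 (1.34 log units; beyond the scatter) and a 3.7-fold lower number from compound 1 to compound 3 (0.56 log units; beyond the scatter), so the two amino substituents measured so far both improved on compound 1. None of these steps shows which way a 4-methoxybenzyl group should go, so no step beyond the scatter is expected, though the uncertainty is wide. The expected change is a 1.4-fold higher number from compound 3 to compound 4 (0.15 log units; within the scatter). For compound 4 the estimated value is 250 nM, with an expected range of 60 nM to 1000 nM.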

Compound 4, half-maximal inhibitory concentration: 3950 nM
Compound 4: the middle estimate sits 16-fold (1.20 log units) below what was measured, and the stated range ends below it.
By their numbers in this assay, from the lowest: compound 2; then compound 3; then compound 1; then compound 4.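

An amino substituent at this place does not by itself lower the number: with (4-methoxybenzyl)amino on the aromatic carbon, this assay shows a 6.2-fold higher number from compound 1 to compound 4 (0.79 log units; beyond the scatter), so compound 4 goes against the drop seen with the two earlier amino groups. Exchanging 2-aminocyclohexyl for 4-methoxybenzyl on the nitrogen gives a 23-fold higher number from compound 3 to compound 4 (1.35 log units; beyond the scatter), and the comparison with the 2-hydroxy-2-methylpropyl group gives a 140-fold higher number from compound 2 to compound 4 (2.13 log units; beyond the scatter), so the choice of group on this nitrogen carries a large effect on the number. The entering group brings an aromatic ring and lacks the hydrogen-bond donor of the group it replaces, and these two differences travel together in this step.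

Nothing among the data given accounts for the rise. From the compounds shown here alone, whether the ring or the missing donor matters stays open, and a cyclohexylmethyl group or a 4-aminobenzyl group on the same nitrogen would help to separate them.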